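Extending a Methoxy Change from One Chain Length to Another

The source may hold more compounds than are shown below. What is called first, only, known or untested is meant among the compounds shown, and "the series" means these compounds.

Compound 1 `CCN(CCCCCCOc1ccc(C(=O)/C=C/c2ccc(N(C)C)cc2)c(O)c1)Cc1ccccc1` and compound 2 `CCN(CCCOc1ccc(C(=O)/C=C/c2ccc(N(C)C)cc2)c(O)c1)Cc1ccccc1` share a core; the difference between the two cores is not broken down here. In an assay on isolated protein for inhibition of Amine oxidase [flavin-containing] A (Homo sapiens) (on this read-out lower numbers stand for stronger inhibition and higher numbers for weaker inhibition), compound 1 gives 31600 nM, while compound 2 gives 82600 nM. Compound 3 `CCN(CCCCCCOc1ccc(C(=O)/C=C/c2ccc(N(C)C)cc2)c(O)c1)Cc1ccccc1OC` differs from compound 1 in one place: methoxy in place of hydrogen on an aromatic carbon. In this assay compound 3 gives 54300 nM. That step, a 1.7-fold higher number from compound 1 to compound 3 (0.24 log units; within the scatter), stays within the usual scatter, so compound 1 and compound 3 cannot be told apart in this assay. Compound 4 `CCN(CCCOc1ccc(C(=O)/C=C/c2ccc(N(C)C)cc2)c(O)c1)Cc1ccccc1OC` is the unmeasured partner of compound 2 and carries the same change: methoxy in place of hydrogen on an aromatic carbon. The place of the change reads the same word for word in both pairs, so this is the same change applied to the other core. Because the earlier step of a 1.7-fold higher number from compound 1 to compound 3 (0.24 log units; within the scatter) stayed within the scatter, compound 4 is expected to behave much like compound 2, with an expected step of about a 1.5-fold higher number from compound 2 to compound 4 (0.16 log units; within the scatter). Compound 4 is therefore estimated at 120000 nM in this assay, plausibly between 50000 nM and 300000 nM.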

Compound 4, half-maximal inhibitory concentration: 26300 nM
Beside the measured number, compound 4's estimate is 4.6-fold (0.66 log units) above it, outside the stated range (below it).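

In this assay, the methoxy change does not carry over unchanged from the core of compound 1 to the core of compound 2: the same change on two cores in this assay, a 1.7-fold higher number (0.24 log units; within the scatter) from compound 1 to compound 3 and a 3.1-fold lower number (0.50 log units; beyond the scatter) from compound 2 to compound 4, 5.4-fold (0.73 log units) apart, beyond the scatter of two such steps

On the core of compound 2 the step is a 3.1-fold lower number from compound 2 to compound 4 (0.50 log units; beyond the scatter), so 2-methoxybenzyl gives stronger inhibition than benzyl there, while on the core of compound 1 the two groups cannot be told apart. This shows that, for these two pairs, the step measured on one core is a poor guide to the same step on the other, but two pairs give no general rule and do not show why the cores differ.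

The compounds shown leave open whether a methoxy on another carbon of the ring, or a chlorine or fluorine in its place, would split between the two cores in the same way. They also leave open how the change would behave with a methyl in place of the ethyl on the amine, or on a core with a longer chain.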